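Methoxy-to-ethoxy variation on a shared aryl core

The compounds below may be only part of what the source reports. "The series", "measured", "known", "first", "only" and "open" are said of these compounds alone.

Two compounds of the series carry numbers in an assay on HEK293 cells for inhibition of cytochrome P450 1A1 (Homo sapiens), read by fluorescence, with stated times of 30 min and 60 min; a higher number here means a weaker inhibitor, a lower number a stronger inhibitor. Compound 1 `CCOc1cc(/C=C/C(=O)c2ccncc2)cc(OC)c1OCC` gives 65 nM. Compound 2 `COc1cc(/C=C/C(=O)c2ccncc2)cc(OC)c1OC` gives 58 nM. Compound 2 has the lower of the two numbers, yet its gap to compound 1 lies within the scatter, so no order between them can be read; swapping two methoxy groups for ethoxy groups leaves the read-out unchanged within the scatter.

Compound 3 `CCOc1c(OC)cc(/C=C/C(=O)c2ccncc2)cc1OC` is not yet measured. It differs from compound 2 by methyl in place of hydrogen on a saturated chain carbon bound to an oxygen on an aromatic ring, which cut one bond further out reads methyl to ethyl, methoxy to ethoxy. Going by the values given here, no measured pair isolates this single change. Among the compounds with values here, the one comparison at hand, compound 1 against compound 2, sits within the scatter, so no step beyond the scatter is expected in this assay in either direction. The expected step from compound 2 to compound 3 is a 1.0-fold higher number from compound 2 to compound 3 (0.01 log units; within the scatter). Compound 3 is estimated at 60 nM, with a range from 35 nM to 110 nM.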

Compound 3, half-maximal inhibitory concentration: 280 nM
The estimate for compound 3 lay 4.7-fold (0.67 log units) below the measured number; the whole stated range lies below it.
By their numbers in this assay, from the lowest: compounds 2 and 1 (each within the scatter of the next); then compound 3.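

In this assay, methoxy to ethoxy at this oxygen is not neutral: the step is a 4.8-fold higher number from compound 2 to compound 3 (0.68 log units; beyond the scatter). Going by these compounds alone, the reverse change, hydrogen in place of methyl on a saturated chain carbon bound to an oxygen on an aromatic ring, gives a 4.3-fold higher number from compound 1 to compound 3 (0.63 log units; beyond the scatter), so the single change raises the number in both directions, depending on what the other alkoxy groups are. The read-out therefore does not follow the number of ethoxy groups, and the effect of one such group depends on the rest of the substitution; nothing measured here explains this.

Still open, going by these compounds, is whether a longer chain such as propoxy, or a hydroxyl on this oxygen, would raise the number further. Also open, on these data alone, is how a single ethoxy on either of the other oxygens would read.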